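Chloro for fluoro on the sulfonyl ring of compound 2

The source may hold more compounds than are shown below. What is called first, only, known or untested is meant among the compounds shown, and "the series" means these compounds.

The three measured compounds share one core and differ around it. Compound 1 `O=S(=O)(/C=C/c1ccccn1)c1ccccc1Cl` gives 618 nM in an assay on U2OS cells for activation of nuclear factor erythroid 2-related factor 2 (Homo sapiens), read by beta-arrestin recruitment, with a stated time of 6 h; on this read-out lower numbers stand for an effect already at smaller amounts and higher numbers for an effect only at larger amounts of compound. Compound 2 `O=S(=O)(/C=C/c1cccnc1)c1ccccc1F` gives 6860 nM in this assay, the highest of the three numbers: compound 1 stands nearest, and compound 3 `O=S(=O)(/C=C/c1cccnc1Cl)c1ccccc1F` furthest, giving 217 nM in this assay. For the measured compounds named here, the one single-point step measured, a 32-fold lower number from compound 2 to compound 3 (1.50 log units; beyond the scatter), concerns the pyridine ring, not the ring that is changed here.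

Compound 4 `O=S(=O)(/C=C/c1cccnc1)c1ccccc1Cl` is not yet measured. Relative to compound 2 the change is chloro in place of fluoro on an aromatic carbon, on an aromatic carbon of a six-membered aromatic ring of carbon only, ortho to a large group. Going by the values given here, no measured step tests this exchange on its own; compounds 1 and 2 differ in two places, so their two values show only that compound 1 sits far lower. The step is therefore expected to be modest, with a lower number somewhat more likely than a higher one, a 2.0-fold lower number from compound 2 to compound 4 (0.29 log units; within the scatter). Compound 4 is expected at 3500 nM, with a range from 1200 nM to 10000 nM.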

Compound 4, half-maximal effective concentration: 2850 nM
Compound 4: the middle estimate sits 1.2-fold (0.09 log units) above what was measured; the measured number falls inside the stated range.
By their numbers in this assay, from the lowest: compound 3; then compound 1; then compound 4; then compound 2.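

In this assay, chloro in place of fluoro on an aromatic carbon, ortho to a large group, taken on its own gives a 2.4-fold lower number from compound 2 to compound 4 (0.38 log units; beyond the scatter), so this position responds to the exchange of one halogen for the other, though modestly. The second step, a 4.6-fold higher number from compound 1 to compound 4 (0.66 log units; beyond the scatter), isolates pyridin-3-yl in place of pyridin-2-yl, so the two-place gap between compound 1 and compound 2 now divides into two single changes, each beyond the usual scatter. Nothing available explains either step.

Going by these compounds, whether bromo, methoxy or an amine on the same carbon would move the number further remains open. So does whether chloro in place of fluoro here would give a similar step on the core of compound 3.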